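The source may report more compounds than this note shows. Statements on the series, on what has been measured and on what is new or still open speak of the compounds shown alone.

For the measured compounds named here, in a functional assay on MCF7 cells (Homo sapiens) for inhibition, read by MTT assay, with a stated time of 72 h (a higher number here means a weaker inhibitor, a lower number a stronger inhibitor), compound 3 `CN(C(=O)NC(=O)c1ccccc1F)c1nc(C(F)(F)F)c(C(=O)N/N=C/c2ccccc2C(F)(F)F)s1` gives 12.2 ug/mL, the higher of the two numbers read, though its only neighbour, compound 2 `CN(C(=O)NC(=O)c1cccc(C(F)(F)F)c1)c1nc(C(F)(F)F)c(C(=O)N/N=C/c2ccccc2C(F)(F)F)s1`, gives 7.69 ug/mL and the step of a 1.6-fold higher number from compound 2 to compound 3 (0.20 log units; within the scatter) stays within the scatter. Compound 1 `CNc1nc(C)c(C(=O)N/N=C/c2ccccc2C(F)(F)F)s1` reaches only a limit in this assay, > 100 ug/mL. Compound 4 `CNc1nc(C(F)(F)F)c(C(=O)N/N=C/c2ccccc2C(F)(F)F)s1` differs from compound 3 by hydrogen in place of ((2-fluorophenyl)carbonyl)carbamoyl on a nitrogen on an aromatic ring. Going by the values given here, no measured step covers that change. Compound 1, which also carries hydrogen on that nitrogen, sits at the limit (the limit of > 100 ug/mL in this assay, at which 1 of the 3 values shown sits). Compound 3 and compound 2 both give numbers. Compound 4 is therefore expected to come out much weaker than compound 3, with an expected step of a 6.6-fold higher number from compound 3 to compound 4 (0.82 log units; beyond the scatter). The estimate for compound 4 is 80 ug/mL, ranging from 25 ug/mL to 250 ug/mL.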

Compound 4, half-maximal inhibitory concentration: > 100 ug/mL
Compound 4: a limit, no number; the forecaster's own chance of this, stated with the estimate: 60%; middle value at least 1.2-fold (0.09 log units) from the limit.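

In this assay, for the compounds shown here, the change to hydrogen from ((2-fluorophenyl)carbonyl)carbamoyl on a nitrogen on an aromatic ring gives an at least 8.1-fold higher number from compound 3 to compound 4 (0.91 log units; beyond the scatter) and is the first readable step at this position, showing that loss of this group matters beyond the scatter. From the compounds shown here alone, compound 4 stands at a limit, so the true size of the step stays unknown: the limit of > 100 ug/mL in this assay, at which 2 of the 4 values shown sit. The step from compound 1 to compound 4 cannot be read, since both are limits. Going by these compounds, whether a smaller acetyl group on that nitrogen would still give a number remains open.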